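Ether chain variation and aldehyde dehydrogenase inhibition

This account rests on a few compounds, and the source may have more. Where it says the series, first, only, none or still open, it means among the compounds named here.

Measured compounds, with values in an assay (Cricetulus griseus) for inhibition of aldehyde dehydrogenase, mitochondrial (Homo sapiens); on this read-out lower numbers stand for stronger inhibition and higher numbers for weaker inhibition:
Compound 1 `NCCCCCCOc1ccc2c(=O)c(-c3ccc(O)cc3)coc2c1`: 100 nM
Compound 2 `O=c1c(-c2ccc(O)cc2)coc2cc(OCCCCCCCCCO)ccc12`: 700 nM

Compound 1 gives the lowest of the two numbers; its nearest neighbour is compound 2, and the step of a 7.0-fold higher number from compound 1 to compound 2 (0.85 log units; beyond the scatter) lies beyond the scatter. That step is the only one measured so far, and it shows that exchanging the terminal amino of the chain for a 3-hydroxypropyl group weakens inhibition.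

Compound 3 `C=CCOc1ccc2c(=O)c(-c3ccc(O)cc3)coc2c1` is not yet measured in this assay. Its difference from compound 1 is vinyl in place of 5-aminopentyl on a saturated chain carbon bound to an oxygen on an aromatic ring. The change removes the amino-bearing part of the chain entirely and leaves only a short allyloxy group. The step from compound 1 to compound 2 is the one that bears on this: there, loss of the amino alone cost a modest amount, so removal of the whole 5-aminopentyl portion is expected to cost at least as much, in the direction of a higher number. A step of about a 10-fold higher number from compound 1 to compound 3 (1.00 log units; beyond the scatter) is therefore expected. For compound 3 the estimate in this assay is 1000 nM, within 250 nM to 5000 nM.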

Compound 3, half-maximal inhibitory concentration: 180 nM
Compound 3: the middle estimate sits 5.6-fold (0.74 log units) above what was measured, and the stated range ends above it.
By their numbers in this assay, from the lowest: compounds 1 and 3 (each within the scatter of the next); then compound 2.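

In this assay, the step of a 1.8-fold higher number from compound 1 to compound 3 (0.26 log units; within the scatter) shows that the 5-aminopentyl portion, amino group included, can give way to vinyl on this saturated chain carbon bound to an oxygen on an aromatic ring without a change beyond the scatter, so the short allyloxy group retains the level of inhibition seen with the (6-aminohexyl)oxy chain. Within the data shown here, the step of a 3.9-fold lower number from compound 2 to compound 3 (0.59 log units; beyond the scatter) places the separation on the other side: of the three ether chains, the one on compound 2 is the one that stands apart, and chain length alone gives no single trend, as compound 1 also carries a long chain yet lies within the scatter of compound 3.

Still open, going by these compounds, is whether the standing of compound 2 follows from its chain length or from its terminal hydroxyl, a question that the chain of compound 1 ending in a hydroxyl instead of an amine, or the chain of compound 2 ending in an amine instead of a hydroxyl, would address. On these data alone, how a carboxylic acid at the chain end, or a simple saturated propyl ether in place of allyl, would read on this assay also remains unknown.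

No supporting measurement is available to explain these readings.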